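This account rests on a few compounds, and the source may have more. Where it says the series, first, only, none or still open, it means among the compounds named here.

Four close relatives built on one shared core are compared in an ADME assay on MT4 cells (Homo sapiens) for cytotoxicity, read by spectrophotometry, with a stated time of 5 days; a lower number here means that less compound is tolerated, a higher number that more compound is tolerated. Compound 1 `Cc1ccc2c(c1)/C(=N/NC(=S)NO)C(=O)N2CN1CCN(c2ccc(Cl)cc2)CC1` gives 335000 nM. Compound 2 `COc1ccc(N2CCN(CN3C(=O)/C(=N\NC(=S)NO)c4cc(C)ccc43)CC2)cc1` differs from compound 1 by methoxy in place of chloro on an aromatic carbon; in this assay compound 2 gives 321000 nM; that exchange made a 1.0-fold lower number from compound 1 to compound 2 (0.02 log units; within the scatter). Compound 3 `CONC(=S)N/N=C1\C(=O)N(CN2CCN(c3ccc(Cl)cc3)CC2)c2ccc(F)cc21` carries a different core, and how its core differs from the core of compound 1 is not broken down here. In this assay compound 3 gives 347000 nM, a number that stands within the usual scatter of both compound 1 and compound 2, so these three cannot be set in any order.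

Compound 4 `CONC(=S)N/N=C1\C(=O)N(CN2CCN(c3ccc(OC)cc3)CC2)c2ccc(F)cc21` has not yet been measured. It differs from compound 3 by methoxy in place of chloro on an aromatic carbon, the same change that led from compound 1 to compound 2, at a place described in the same words. Because the earlier exchange gave a 1.0-fold lower number from compound 1 to compound 2 (0.02 log units; within the scatter), the same change is expected to make a 1.1-fold lower number from compound 3 to compound 4 (0.02 log units; within the scatter). Compound 4 is therefore estimated at 330000 nM, with a range from 180000 nM to 600000 nM that allows for the usual scatter of such measurements.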

Compound 4, half-maximal cytotoxic concentration: 276000 nM
For compound 4 the middle estimate is 1.2-fold (0.08 log units) above the measured one; measured number inside the range.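

In this assay, replacing the 4-chlorophenyl group with 4-methoxyphenyl on the fluorinated core gives a 1.3-fold lower number from compound 3 to compound 4 (0.10 log units; within the scatter). Set beside the same exchange on the core of compound 1, the two steps show no difference that can be told from ordinary measurement noise: the same change on two cores in this assay, a 1.0-fold lower number (0.02 log units; within the scatter) from compound 1 to compound 2 and a 1.3-fold lower number (0.10 log units; within the scatter) from compound 3 to compound 4, 1.2-fold (0.08 log units) apart, within the scatter of two such steps So in these two pairs the change carries from one core to the other without a visible effect on the tolerated concentration, but neither step is large enough to show a real shift, a small one could be hidden in the scatter, and two pairs do not make a rule for the whole series.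

The compounds shown leave open whether other groups on that aromatic carbon, such as an amine, a carboxylic acid or a longer chain, would also leave the number within the scatter. They also leave open how this exchange behaves on any core beyond these two, or in any read-out other than cytotoxicity in these cells.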